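Methyl Branching Beside the Triazole Hydroxyethoxy Arm

The compounds below may be only part of what the source reports. "The series", "measured", "known", "first", "only" and "open" are said of these compounds alone.

For the measured compounds named here, in an assay on isolated protein for inhibition of Indoleamine 2,3-dioxygenase 2 (Homo sapiens) (a higher number here means a weaker inhibitor, a lower number a stronger inhibitor), compound 2 `OCCOCc1cn(CCNc2nonc2/C(=N/O)Nc2ccc(F)c(Br)c2)nn1` gives 144 nM, the lowest of the two numbers so far. Going by the values given here, compound 1 `CCC(C)(O)c1cn(CCNc2nonc2/C(=N/O)Nc2ccc(F)c(Br)c2)nn1` gives 958 nM, and a 6.7-fold lower number from compound 1 to compound 2 (0.82 log units; beyond the scatter) is the only step at hand. Compound 3 `CC(OCCO)c1cn(CCNc2nonc2/C(=N/O)Nc2ccc(F)c(Br)c2)nn1` carries methyl in place of hydrogen on a saturated chain carbon bound to an aromatic carbon and an oxygen on a saturated carbon. That single step bears on it, since it also traded a branched carbon bound to the aromatic carbon for a less branched one, so a modest move back upward is expected for compound 3, of about a 1.6-fold higher number from compound 2 to compound 3 (0.20 log units; within the scatter). Compound 3 is therefore estimated at 230 nM, with a range from 90 nM to 600 nM.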

Compound 3, half-maximal inhibitory concentration: 930 nM
For compound 3 the middle estimate is 4.0-fold (0.61 log units) below the measured one, and the stated range ends below it.
By their numbers in this assay, from the lowest: compound 2; then compounds 3 and 1 (each within the scatter of the next).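

In this assay, methyl at the saturated chain carbon bound to an aromatic carbon and an oxygen is enough to lose what the (2-hydroxyethoxy)methyl arm of compound 2 had gained (a 6.5-fold higher number from compound 2 to compound 3 (0.81 log units; beyond the scatter)). The 1-(2-hydroxyethoxy)ethyl and 1-hydroxy-1-methylpropyl groups then read alike (a 1.0-fold lower number from compound 1 to compound 3 (0.01 log units; within the scatter)), so among these compounds only the unbranched arm of compound 2 stands apart. Nothing available explains why this methyl has so large an effect.

As far as these compounds go, whether an ethyl or a cyclopropyl at this carbon would read like methyl stays open. So does whether an amine in place of the terminal hydroxyl of the arm would change the number.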